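A few compounds are considered here, and "the series" means these few. Any claim that something is new, unique, unknown or untested is made for them only; others in the source may bear on it.

Series values in a functional assay on DU-145 cells (Homo sapiens) for inhibition, read by trypan blue exclusion, with a stated time of 96 h; a higher number here means a weaker inhibitor of growth, a lower number a stronger inhibitor of growth:

- compound 1 `Cc1ccc(CS/C(=C/c2c(O)cc(O)cc2O)C(=O)c2ccc(Cl)cc2)cc1` gives 50000 nM
- compound 2 `Cc1ccc(CS/C(=C/c2ccccc2F)C(=O)c2ccc(Cl)cc2)cc1` gives 10000 nM
- compound 3 `Cc1ccc(CS/C(=C/c2ccc(C)s2)C(=O)c2ccc(Cl)cc2)cc1` gives 50000 nM
- compound 4 `Cc1ccc(CS/C(=C/c2cc(Cl)cc(Cl)c2)C(=O)c2ccc(Cl)cc2)cc1` is not yet measured

Compound 3 shares the highest number of the three with compound 1, and compound 2 lies clearly lower. The step to compound 4 puts 3,5-dichlorophenyl in place of 5-methylthiophen-2-yl on a double-bonded chain carbon bound to a double-bonded chain carbon.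

Three measured steps change this same group. The step of a 5.0-fold lower number from compound 1 to compound 2 (0.70 log units; beyond the scatter) and the step of a 5.0-fold higher number from compound 2 to compound 3 (0.70 log units; beyond the scatter) are both modest, while the step of no change at the digits printed from compound 1 to compound 3 (within the scatter) shows nothing. Among the compounds with values here, the only measured aryl group carrying a halogen here is the 2-fluorophenyl of compound 2 at 10000 nM, so this is the nearest precedent, though a single one. A modest drop in this assay is therefore expected, slightly smaller than the measured steps: the expected step is a 3.3-fold lower number from compound 3 to compound 4 (0.52 log units; beyond the scatter). For compound 4 the estimated value is 15000 nM, with an expected range of 4000 nM to 50000 nM.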

Compound 4, concentration for 50% growth inhibition: 10000 nM
Beside the measured number, compound 4's estimate is 1.5-fold (0.18 log units) above it, and the stated range covers the measured number.
By their numbers in this assay, from the lowest: compounds 2 and 4 (each within the scatter of the next); then compounds 1 and 3 (each within the scatter of the next).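

In this assay, 3,5-dichlorophenyl gives a 5.0-fold lower number from compound 3 to compound 4 (0.70 log units; beyond the scatter) and a 5.0-fold lower number from compound 1 to compound 4 (0.70 log units; beyond the scatter) and thereby shows that the lower level at this place does not rest on the 2-fluorophenyl of compound 2 alone. With no change at the digits printed from compound 2 to compound 4 (within the scatter) in the same assay, the change in halogen and substitution pattern separates nothing, and the four compounds fall into two level pairs with none going against the split: compounds 2 and 4 with halogen-bearing phenyl groups, and compounds 1 and 3 without halogen. No supporting data explain this split.

An unsubstituted phenyl group would show whether the halogen or the phenyl ring goes with the lower level. Also open, as far as these compounds go, is how an amine or a carboxylic acid on that ring would read.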